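This account rests on a few compounds, and the source may have more. Where it says the series, first, only, none or still open, it means among the compounds named here.

Working notes on the series. Among the measured compounds shown here, in an assay on isolated protein for inhibition of G protein-coupled receptor kinase 5 (Homo sapiens), read by TR-FRET, with stated times of 10 min and 1 h (a lower number here means a stronger inhibitor, a higher number a weaker inhibitor), compound 2 `Nc1ncc(-c2cnn(C3CCNCC3)c2)cc1-c1nc2ccc(-c3cn[nH]c3)cc2o1` gives 1780 nM, the lowest of the two numbers measured so far; compound 1 `CN(C)COc1cccc(-c2cnc(N)c(-c3nc4cccc(-c5ccccn5)c4o3)c2)c1` gives 5100 nM, a gap beyond the scatter. Compound 3 `COc1ccc(-c2ccc3nc(-c4cc(-c5cnn(C6CCNCC6)c5)cnc4N)oc3c2)cc1` differs from compound 2 only in 4-methoxyphenyl in place of 1H-pyrazol-4-yl on an aromatic carbon. For the measured compounds named here, no measured pair isolates this change, so nothing here fixes its size; the expectation is a modest loss, with the step from compound 2 to compound 3 estimated at a 1.8-fold higher number from compound 2 to compound 3 (0.25 log units; within the scatter). Compound 3 is accordingly expected to come in at about 3200 nM, within a range of 1000 nM to 10000 nM.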

Compound 3, half-maximal inhibitory concentration: 3220 nM
Compound 3: the middle estimate sits 1.0-fold (0.00 log units) below what was measured; the range from low to high includes it.
By their numbers in this assay, from the lowest: compounds 2, 3 and 1 (each within the scatter of the next, the first and the last beyond it).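

With 4-methoxyphenyl in place of 1H-pyrazol-4-yl on this aromatic carbon, this assay shows a 1.8-fold higher number from compound 2 to compound 3 (0.26 log units; within the scatter), a step that cannot be told apart from repeat scatter. This position thus carries a six-membered aromatic ring of carbon only, without a hydrogen-bond donor, and the number stays within the scatter of compound 2. Nothing at hand bears on why the step has this size. Going by these compounds, whether a carboxylic acid or a simple amine on this carbon would give a step beyond the scatter remains open.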